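Cytotoxicity in the series: from compound 3 to compound 4

A few compounds are considered here, and "the series" means these few. Any claim that something is new, unique, unknown or untested is made for them only; others in the source may bear on it.

Measured compounds:
Compound 1 `O=C(COc1cccc2ccccc12)N/N=C/c1ccc(O)cc1` gives in an ADME assay on HEL cells (Homo sapiens) for cytotoxicity (on this read-out lower numbers stand for higher toxicity in this test and higher numbers for lower toxicity in this test), a value of 20 ug/mL.
Compound 2 `O=C(COc1cccc2ccccc12)N/N=C/c1cccc(Br)c1` gives in this assay a value of 100 ug/mL.
Compound 3 `O=C(COc1cccc2ccccc12)N/N=C/c1ccc(Br)cc1` gives in this assay only a limit, > 100 ug/mL.

Compound 3 stands at the top of the shown numbers, but its value is a limit and not a number (the limit of > 100 ug/mL in this assay, at which 1 of the 3 values shown sits), so its position relative to compound 2 is open: a number no lower from compound 2 to compound 3 (the limit leaves the size open). The step to compound 4 `COc1ccc(/C=N/NC(=O)COc2cccc3ccccc23)cc1` is methoxy in place of bromo on an aromatic carbon. Of the measured steps, the one that bears most on it is an at least 5.0-fold higher number from compound 1 to compound 3 (0.69 log units; beyond the scatter), which exchanges a hydroxy for a bromo at the same place. Alongside it, a 5.0-fold higher number from compound 1 to compound 2 (0.70 log units; beyond the scatter) shows a modest step in the same direction. Methoxy sits between hydroxy and bromo in kind, so a number lower than the limit of compound 3 and higher than compound 1 is expected. Compound 4 is estimated at 50 ug/mL, with a range from 20 ug/mL to 100 ug/mL, which means an expected step of an at least 2.0-fold lower number from compound 3 to compound 4 (0.30 log units; that floor lies within the scatter), in the direction of higher toxicity in this assay.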

Compound 4, minimum cytotoxic concentration in the HEL assay: 20 ug/mL
Compound 4: the middle estimate sits 2.5-fold (0.40 log units) above what was measured, and the stated range covers the measured number.
By their numbers in the HEL assay, from the lowest: compounds 1 and 4 (each within the scatter of the next); then compound 2.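

In the HEL assay, no change at the digits printed from compound 1 to compound 4 (within the scatter), while an at least 5.0-fold lower number from compound 3 to compound 4 (0.69 log units; beyond the scatter) and a 5.0-fold lower number from compound 2 to compound 4 (0.70 log units; beyond the scatter), so at this position on the ring the methoxy compound reads with the hydroxy compound and apart from both bromo compounds, which means that capping the oxygen with a methyl group does not shift the minimum cytotoxic concentration. As far as these compounds go, for compound 3, the value of > 100 ug/mL is a limit and not a number, so the true size of that step remains unknown. In a physicochemical assay for lipophilicity, measured as octanol-water partition (on this read-out higher numbers stand for higher lipophilicity and lower numbers for lower lipophilicity), compound 3 gives 4.81 and compound 4 gives 3.77, so in this one pair the lower minimum cytotoxic concentration goes with the lower partition coefficient, though a single pair establishes no link between the two.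

From the compounds shown here alone, it remains open whether that pairing holds across the rest of the series and how far compound 3 lies past its limit. An amine or a carboxylic acid at this position, or a longer chain on the oxygen, would show whether the grouping of hydroxy with methoxy extends to other groups.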